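This account rests on a few compounds, and the source may have more. Where it says the series, first, only, none or still open, it means among the compounds named here.

Compound 1, `COCOc1cc(/C=C/C(=O)OCC(=O)Nc2ccc(Cl)cc2)ccc1OCc1ccccc1`: > 200000 nM
Compound 2, `COc1ccc(/C=C/C(=O)OCC(=O)Nc2ccc(Cl)cc2)cc1OC`: 81900 nM

Both compounds were tested in a functional assay on ECa-109 cells (Homo sapiens) for cytotoxicity, read by MTT assay, with a stated time of 72 h; a lower number here means a stronger inhibitor, a higher number a weaker inhibitor. For compound 1 the result is not a number but a limit of the assay, (the limit of > 200000 nM in this assay, at which 1 of the 2 values shown sits), so its position on the scale is known only as a boundary and not as a point. Compound 2 gives a measured value in this assay, 81900 nM. For the measured compounds named here, no single-point step between measured compounds is available here, so there is no measured change to lean on.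

Compound 3, `COCOc1cc(/C=C/C(=O)OCC(=O)NCc2ccco2)ccc1OCc1ccccc1`, differs from compound 1 in one place: (furan-2-yl)methyl in place of 4-chlorophenyl on an amide-type nitrogen. With compound 1 sitting at a limit, no measured step sets the size of this change, and nothing shown speaks for a gain that would go beyond the usual scatter. The expected step from compound 1 to compound 3 is therefore an at least 1.3-fold lower number from compound 1 to compound 3 (0.12 log units; that floor lies within the scatter), essentially none beyond the scatter. On that basis compound 3 is estimated at 150000 nM in this assay, with a range from 40000 nM to 400000 nM.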

Compound 3, half-maximal inhibitory concentration: > 200000 nM
Compound 3 was reported as a limit; the forecaster's own chance of this, stated with the estimate: 60%; at least 1.3-fold (0.12 log units) between middle value and limit.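

In this assay compound 3 gives > 200000 nM, which is a limit of the assay and not a number. Compound 1 also stands at a limit, so no step between compound 1 and compound 3 can be read: the limit of > 200000 nM in this assay, at which 2 of the 3 values shown sit.

The compounds shown leave open whether (furan-2-yl)methyl in place of 4-chlorophenyl on an amide-type nitrogen changes the cytotoxicity at all.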